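Chloro for fluoro on a second quinolone core

A few compounds are considered here, and "the series" means these few. Any claim that something is new, unique, unknown or untested is made for them only; others in the source may bear on it.

Three compounds sharing a core have been measured in a functional assay on V79 cells (Cricetulus griseus) for cytotoxicity, read by colony formation; a lower number here means a stronger inhibitor, a higher number a weaker inhibitor:
compound 1 `CNCC1(C)CCN(c2c(F)cc3c(=O)c(C(=O)O)cn(C4CC4)c3c2F)C1` gives 8 ug/mL;
compound 2 `CNCC1(C)CCN(c2c(F)cc3c(=O)c(C(=O)O)cn(C4CC4)c3c2Cl)C1` gives 23 ug/mL;
compound 3 `NC1CCCN(c2c(F)cc3c(=O)c(C(=O)O)cn(C4CC4)c3c2F)C1` gives 53 ug/mL.

Compound 2 differs from compound 1 by chloro in place of fluoro on an aromatic carbon, a change that gave a 2.9-fold higher number from compound 1 to compound 2 (0.46 log units; beyond the scatter). Compound 3 differs from compound 1 in its core by 3-aminopiperidin-1-yl in place of 3-methyl-3-((methylamino)methyl)pyrrolidin-1-yl on an aromatic carbon, which gave a 6.6-fold higher number from compound 1 to compound 3 (0.82 log units; beyond the scatter). Compound 4 `NC1CCCN(c2c(F)cc3c(=O)c(C(=O)O)cn(C4CC4)c3c2Cl)C1` is not yet measured; it differs from compound 3 by chloro in place of fluoro on an aromatic carbon. This is the same kind of change as that from compound 1 to compound 2, not the same, since the place is ortho to a 3-aminopiperidin-1-yl group here rather than ortho to a 3-methyl-3-((methylamino)methyl)pyrrolidin-1-yl group. Resting on the single earlier step of a 2.9-fold higher number from compound 1 to compound 2 (0.46 log units; beyond the scatter), a step of similar size is expected, a 2.5-fold higher number from compound 3 to compound 4 (0.39 log units; beyond the scatter). Compound 4 is therefore estimated at 130 ug/mL in this assay, between 65 ug/mL and 260 ug/mL.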

Compound 4, half-maximal inhibitory concentration: 24 ug/mL
Beside the measured number, compound 4's estimate is 5.4-fold (0.73 log units) above it, outside the stated range (below it).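

In this assay, chloro in place of fluoro did not carry over from one side chain to the other, for here it gave a 2.2-fold lower number from compound 3 to compound 4 (0.34 log units; beyond the scatter) and so ran the opposite way to the earlier step: the same change on two cores in this assay, a 2.9-fold higher number (0.46 log units; beyond the scatter) from compound 1 to compound 2 and a 2.2-fold lower number (0.34 log units; beyond the scatter) from compound 3 to compound 4, 6.3-fold (0.80 log units) apart, beyond the scatter of two such steps. Exchanging the side chain likewise depends on which halogen is present, for with chloro it gave a 1.0-fold higher number from compound 2 to compound 4 (0.02 log units; within the scatter) and so no change beyond the scatter: the same change on two cores in this assay, a 6.6-fold higher number (0.82 log units; beyond the scatter) from compound 1 to compound 3 and a 1.0-fold higher number (0.02 log units; within the scatter) from compound 2 to compound 4, 6.3-fold (0.80 log units) apart, beyond the scatter of two such steps. The two changes are therefore not independent in these four compounds, but four compounds do not show why, nor how any other side chain would respond.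

As far as these compounds go, it remains open whether bromo or a plain hydrogen in that place would follow chloro or fluoro. From the compounds shown here alone, it also remains open what a simple 3-aminopyrrolidin-1-yl group would do on either halogen.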